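The source may report more compounds than this note shows. Statements on the series, on what has been measured and on what is new or still open speak of the compounds shown alone.

Of the compounds shown here, three have so far been tested in a functional assay on MCF7 cells (Homo sapiens) for cytotoxicity; a lower number here means that less compound is needed, a higher number that more compound is needed for the effect. For the measured compounds named here, compound 1 `COc1cc(/C=C/c2ccc(C(C)C)cc2)cc(OC)c1OC` gives 18.4 uM, the only true number in the set. Compound 2 `COc1ccc(/C=C/c2cc(OC)c(OCc3ccccc3)c(OC)c2)cc1` reads > 25 uM, which is a limit of the assay and not a number. Compound 3 `COc1ccc(/C=C\c2cc(OC)c(OC(C)=O)c(OC)c2)cc1` reads > 25 uM, again a limit of the assay and not a number. Compound 1 is thus the only one with a firm figure to compare against, and the rest of the evidence is the limit of > 25 uM in this assay, at which 2 of the 3 values shown sit.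

The next compound, compound 4 `COc1cc(/C=C/c2ccc(C(C)(C)C)cc2)cc(OC)c1OC`, keeps the core of compound 1 and alters one spot (methyl in place of hydrogen on a saturated chain carbon bound to an aromatic carbon and two saturated chain carbons). Methyl takes the place of hydrogen on a saturated chain carbon bound to an aromatic carbon and two saturated chain carbons, which turns isopropyl into tert-butyl.

Going by the values given here, no measured pair in this set shows what such a swap does, so there is no direct precedent to lean on. Starting from compound 1 at 18.4 uM, the expectation in this assay is no step beyond the usual scatter, in either direction. The estimated change is a 1.0-fold lower number from compound 1 to compound 4 (0.01 log units; within the scatter) and would count as no real shift. For compound 4 the estimated value is 18 uM, with an expected range from 9 uM to 32 uM.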

Compound 4, concentration for half-maximal effect: > 25 uM
Compound 4 was reported as a limit; the forecaster's own chance of this, stated with the estimate: 30%; middle value at least 1.3-fold (0.14 log units) away from the limit.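

For the compounds shown here, replacing isopropyl with tert-butyl on the core of compound 1 gives the first step in this set that can be tied to a single place: an at least 1.3-fold higher number from compound 1 to compound 4 (0.13 log units; that floor lies within the scatter). In this assay compound 4 reads > 25 uM, which is a limit of the assay and not a number, so this step has a floor but no known upper end, and its true size could be small or large. The added methyl therefore brings no sign of a gain at this position, while compound 1 remains the only compound with a firm figure and the rest of the comparison rests on a single ceiling: the limit of > 25 uM in this assay, at which 3 of the 4 values shown sit.

The compounds shown leave open whether a firm number can be obtained with a plain ethyl group at this place, or with a carboxylic acid or an amine there instead of the branched chain. They also leave open how much of the activity of compound 1 depends on the isopropyl group itself, as no compound shown has a simple hydrogen at this place on the same core.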